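This account rests on a few compounds, and the source may have more. Where it says the series, first, only, none or still open, it means among the compounds named here.

Measured compounds:
Compound 1 (`Cc1nnc(SCC(=O)N/N=c2/scc(-c3ccccc3)n2-c2ccccc2)s1`): in a functional assay on C6 cells (Rattus norvegicus) for cytotoxicity, read by MTT assay, with a stated time of 24 h (a higher number here means a weaker inhibitor, a lower number a stronger inhibitor), compound 1 gives > 200 ug/mL, which is a limit of the assay.
Compound 2 (`Cc1nnc(SCC(=O)N/N=c2/scc(-c3ccc([N+](=O)[O-])cc3)n2-c2ccccc2)s1`): in this assay compound 2 gives "not determined" (no result reported).
Compound 3 (`COc1ccc(-c2cs/c(=N/NC(=O)CSc3nnnn3-c3ccccc3)n2-c2ccccc2)cc1`): in this assay compound 3 gives "not determined" (no result reported).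

Among the compounds with values here, compound 3 thus stands without a single number in this assay, and no other compound offers a step to compare it with. One of the values shown is the limit of > 200 ug/mL in this assay, at which 1 of the 3 values shown sits. Compound 4 (`COc1ccc(-c2cs/c(=N/NC(=O)CSc3nnc(C)s3)n2-c2ccccc2)cc1`) differs from compound 3 by 5-methyl-1,3,4-thiadiazol-2-yl in place of 1-phenyl-1H-tetrazol-5-yl on a sulfur, the sulfur otherwise bound to a saturated chain carbon. Within the data shown here, with no measured step to draw on, no change beyond the usual scatter is expected from this exchange in this assay. Compound 4 is therefore estimated at about 200 ug/mL, with a range from 60 ug/mL to 400 ug/mL.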

Compound 4, half-maximal inhibitory concentration: 18.7 ug/mL
Beside the measured number, compound 4's estimate is 11-fold (1.03 log units) above it; the measured number lies below the stated range.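

Methoxy in place of hydrogen on an aromatic carbon brings an at least 10-fold lower number from compound 1 to compound 4 (1.02 log units; beyond the scatter) in this assay and so shows that this aromatic carbon can carry a change that registers in the assay. On these data alone, compound 1 stands at a limit of the assay, so the step's full size stays unknown: the limit of > 200 ug/mL in this assay, at which 1 of the 4 values shown sits.

As far as these compounds go, whether an amine or a hydroxyl group on the same aromatic carbon would act like methoxy remains open. So does the effect of exchanging 1-phenyl-1H-tetrazol-5-yl for 5-methyl-1,3,4-thiadiazol-2-yl on the sulfur, a step that cannot be read.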